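The source may hold more compounds than are shown below. What is called first, only, known or untested is meant among the compounds shown, and "the series" means these compounds.

In a functional assay on A549 cells (Homo sapiens) for antiproliferative activity, read by MTT assay, with a stated time of 48 h (a higher number here means a weaker inhibitor of growth, a lower number a stronger inhibitor of growth), compound 1 (`CCOC(=O)N1N=C(c2ccccc2)CC1c1cc(OC)c(OC)c(OC)c1`) reads 6680 nM while compound 2 (`COC(=O)N1N=C(c2cccc(OC)c2)CC1c1cc(OC)c(OC)c(OC)c1`) reads 2590 nM on the same scale. Compound 2 therefore holds the lower of the two numbers and is the stronger growth inhibitor of this pair, by a gap beyond the usual scatter of repeat measurements. These two compounds differ in more than one place, so their gap cannot be tied to any single structural change.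

The next molecule, compound 3 (`CCOC(=O)N1N=C(c2cccc(OC)c2)CC1c1cc(OC)c(OC)c(OC)c1`), differs from compound 2 in one place only (methyl in place of hydrogen on a saturated chain carbon bound to an oxygen next to a carbonyl group): methyl in place of hydrogen on a saturated chain carbon bound to an oxygen next to a carbonyl group. Methoxycarbonyl thus becomes ethoxycarbonyl.

For the measured compounds named here, no measured pair shows this change alone, so the expectation rests on thin evidence. In this assay the added methyl is expected to give only a small step, perhaps a slight rise in the number, and quite possibly nothing beyond the scatter. The expected move is a 1.2-fold higher number from compound 2 to compound 3 (0.09 log units; within the scatter) in this estimate. For compound 3 the estimate is 3200 nM with an expected range from 1400 nM to 7000 nM in repeat measurements.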

Compound 3, concentration for 50% growth inhibition: 5920 nM
Compound 3: the middle estimate sits 1.9-fold (0.27 log units) below what was measured; the measured number falls inside the stated range.
By their numbers in this assay, from the lowest: compound 2; then compounds 3 and 1 (each within the scatter of the next).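

In this assay the single added methyl on a saturated chain carbon bound to an oxygen next to a carbonyl group, which turns methoxycarbonyl into ethoxycarbonyl, gives a 2.3-fold higher number from compound 2 to compound 3 (0.36 log units; beyond the scatter) and so weakens growth inhibition measurably, even though the change is only one carbon. With ethoxycarbonyl kept in place, methoxy in place of hydrogen on an aromatic carbon gives a 1.1-fold lower number from compound 1 to compound 3 (0.05 log units; within the scatter) and so makes no difference that can be told apart from repeat measurements. Compound 1 and compound 2 differ in both of these places, and now each change can be read alone: only the methyl step lies beyond the scatter.

No measurement available here bears on why the added methyl has this effect. As far as these compounds go, it also remains open whether a longer chain such as propyl, or a branched one such as isopropyl, would continue the same trend at this position, and whether the methoxy change would still make no clear difference with methoxycarbonyl in place of ethoxycarbonyl.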